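Chloro in Place of Methoxy: Compound 3 to Compound 4

The source may hold more compounds than are shown below. What is called first, only, known or untested is meant among the compounds shown, and "the series" means these compounds.

Of the compounds shown here, three that share one core have been measured in an assay on isolated protein (Cricetulus griseus) for binding affinity to Alpha-1B adrenergic receptor (Mesocricetus auratus), read by radioligand binding; a higher number here means a weaker inhibitor, a lower number a stronger inhibitor. Compound 1 `CC(=O)Nc1cccc2c1CCCC2c1c[nH]cn1` carries an acetamide group. In this assay compound 1 gives < 10000 nM, which is a limit of the assay rather than a number. Compound 2 `CS(=O)(=O)Nc1ccc(O)c2c1CCCC2c1c[nH]cn1` carries a methanesulfonamide and a free hydroxyl. In this assay compound 2 gives < 10000 nM, again a limit. Compound 3 `COc1ccc(NS(C)(=O)=O)c2c1C(c1c[nH]cn1)CCC2` bears a methoxy where compound 2 bears the hydroxyl. In this assay compound 3 gives < 10000 nM, also a limit. The step that the two limits leave unreadable from compound 2 to compound 3 therefore cannot be read, and compound 3 stands where the other two stand, at the limit described by the limit of < 10000 nM in this assay, at which 3 of the 3 values shown sit.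

Compound 4 `CS(=O)(=O)Nc1ccc(Cl)c2c1CCCC2c1c[nH]cn1` differs from compound 3 by chloro in place of methoxy on an aromatic carbon. Within the data shown here, no measured step bears directly on this exchange; the only step available is unreadable, and every value shown sits at the same limit. The expectation for compound 4 therefore rests solely on the three compounds all falling under that limit, and no step beyond the scatter is expected in this assay. Compound 4 is expected to give 2000 nM, within a range from 200 nM to 10000 nM. The step that the limit leaves unreadable from compound 3 to compound 4 is thus estimated to stay within the scatter.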

Compound 4, inhibition constant: < 10000 nM
Compound 4 ended at the assay's limit; the forecaster's own chance of this, stated with the estimate: 50%; the middle value lies beyond the limit too.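

In this assay compound 4 gives < 10000 nM, which is a limit of the assay and not a number, so the steps to it from compound 2 and from compound 3 cannot be read. The compounds shown leave open how strongly any of them binds, and whether chloro, methoxy or hydroxy on that aromatic carbon makes any difference: the limit of < 10000 nM in this assay, at which 4 of the 4 values shown sit.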